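The source may hold more compounds than are shown below. What is called first, only, known or untested is meant among the compounds shown, and "the series" means these compounds.

Measured so far in an assay on cells for inhibition of histone deacetylase 4 (Homo sapiens), read by fluorescence, with a stated time of 30 min; on this read-out lower numbers stand for stronger inhibition and higher numbers for weaker inhibition:
compound 1 `O=C1NC(=O)/C(=C\c2ccc(OCC(=O)N3N=C(c4ccccc4)CC3c3ccc(F)cc3F)cc2)S1` gives 2200 nM
compound 2 `O=C1NC(=O)/C(=C\c2ccc(OCC(=O)N3N=C(c4ccccc4)CC3c3ccc(Br)cc3)cc2)S1` gives 1200 nM

Compound 1 sits at the upper end of these two numbers, separated from compound 2 by a 1.8-fold lower number from compound 1 to compound 2 (0.26 log units; within the scatter), within the scatter. Compound 3 `O=C1NC(=O)/C(=C\c2ccc(OCC(=O)N3N=C(c4ccc(F)cc4)CC3c3ccc(F)cc3F)cc2)S1` differs from compound 1 by fluoro in place of hydrogen on an aromatic carbon, or, cut one bond further out, phenyl to 4-fluorophenyl. Among the compounds with values here, the only measured step, a 1.8-fold lower number from compound 1 to compound 2 (0.26 log units; within the scatter), alters the group on a saturated ring carbon, not the aromatic carbon touched here, so it bears on the change only loosely and was itself within the scatter. Expected, therefore, is no change at the digits printed from compound 1 to compound 3 (within the scatter), nothing beyond the scatter. Compound 3 is estimated at 2200 nM, with a range from 1000 nM to 4800 nM.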

Compound 3, half-maximal inhibitory concentration: 1600 nM
The estimate for compound 3 lay 1.4-fold (0.14 log units) above the measured number, within the range that was stated.
By their numbers in this assay, from the lowest: compounds 2, 3 and 1 (each within the scatter of the next).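

In this assay, fluoro in place of hydrogen on the aromatic carbon para to a large group gives a 1.4-fold lower number from compound 1 to compound 3 (0.14 log units; within the scatter) and so no change that can be told from scatter. Within the data shown here, this is the first reading at this aromatic carbon, since the earlier step altered only the group on a saturated ring carbon. No measurement bears on the reason for this result.

From the compounds shown here alone, whether methoxy, an amine or a carboxylic acid at this place would shift the number beyond the scatter stays open. Also open, going by these compounds, is whether 4-fluorophenyl gives the same result alongside the 4-bromophenyl group of compound 2.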